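This account rests on a few compounds, and the source may have more. Where it says the series, first, only, none or still open, it means among the compounds named here.

Measured compounds:
compound 1, `CC(C)N(C(=O)CN1C=CN(c2ccccc2)C(=O)[C@H](Cc2n[nH]c3ccccc23)C1=O)c1ccccc1`, 295 nM
compound 2, `O=C1[C@@H](Cc2n[nH]c3ccccc23)C(=O)N(c2ccccc2)C=CN1CC(=O)N1CCCCc2ccccc21`, 1.59 nM

Both were tested in a functional assay on CHO cells for agonist activity at Melanocyte-stimulating hormone receptor (Homo sapiens), read by a luciferase reporter, with a stated time of 4 h; on this read-out lower numbers stand for an effect already at smaller amounts and higher numbers for an effect only at larger amounts of compound. Compound 1 gives 295 nM, the highest of the two numbers, and compound 2 gives 1.59 nM, which is a 190-fold lower number from compound 1 to compound 2 (2.27 log units; beyond the scatter). That step exchanges the group on the carbonyl carbon and says nothing about the fused ring system carried on the shared core.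

Compound 3, `CC(C)N(C(=O)CN1C=CN(c2ccccc2)C(=O)[C@H](Cc2n[nH]c3cc(F)ccc23)C1=O)c1ccccc1`, differs from compound 1 at that fused ring system: fluoro in place of hydrogen on an aromatic carbon, on an aromatic carbon of a six-membered aromatic ring of carbon only, part of a fused or bridged system of two rings, meta to a fused ring and para to a fused ring. Within the data shown here, no measured step bears on this place, so nothing points to a change in this assay beyond the scatter in either direction. Compound 3 is therefore expected to give about 295 nM, between 90 nM and 950 nM. The step from compound 1 to compound 3 is expected to be no change at the digits printed from compound 1 to compound 3 (within the scatter).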

Compound 3, half-maximal effective concentration: 35.5 nM
The estimate for compound 3 lay 8.3-fold (0.92 log units) above the measured number; the whole stated range lies above it.
By their numbers in this assay, from the lowest: compound 2; then compound 3; then compound 1.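

The fused ring system on the shared core turns out to matter in this assay: fluoro in place of hydrogen, on the aromatic carbon meta to a fused ring and para to a fused ring, gives an 8.3-fold lower number from compound 1 to compound 3 (0.92 log units; beyond the scatter) with just one heavy atom entering. Among these compounds, until now, the only measured step was at the group on the carbonyl carbon, so this is the first sign that the read-out also responds to a change on this ring. It shows the size and direction of the step for this one replacement on the core of compound 1, and no more.

Open, going by these compounds, is whether chloro or methoxy at this same aromatic carbon would move the number as fluoro does, and whether fluoro would have a similar effect with the group on the carbonyl carbon of compound 2. No measurement bearing on the cause of this step is available.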